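Two ester changes on one dihydropyridine-type series

A few compounds are considered here, and "the series" means these few. Any claim that something is new, unique, unknown or untested is made for them only; others in the source may bear on it.

Measured so far:
- compound 1 `COC(=O)C1=C(C)NC(C)=C(C(=O)OC(C)C)C1c1cnc(SC)n1Nc1ccccc1`: 6.35 nM
- compound 2 `COCCOC(=O)C1=C(C)NC(C)=C(C(=O)OC)C1c1cnc(SC)n1Nc1ccccc1`: 9.65 nM
- compound 3 `CCOC(=O)C1=C(C)NC(C)=C(C(=O)OC(C)C)C1c1cnc(SC)n1Nc1ccccc1`: 3.22 nM

All three compounds were measured in an assay on isolated protein (strain albino) for antagonist activity at Voltage-dependent L-type calcium channel subunit alpha-1C (Cavia porcellus); on this read-out lower numbers stand for stronger inhibition and higher numbers for weaker inhibition. Compound 1 gives 6.35 nM, compound 2 gives 9.65 nM and compound 3 gives 3.22 nM. The step of a 1.5-fold higher number from compound 1 to compound 2 (0.18 log units; within the scatter) is the result of the change (2-methoxyethyl in place of isopropyl on an oxygen next to a carbonyl group). The step of a 2.0-fold lower number from compound 1 to compound 3 (0.29 log units; within the scatter) follows from methyl in place of hydrogen on a saturated chain carbon bound to an oxygen next to a carbonyl group. Compound 3 has the lowest number of the three, but its step to compound 1 is within the scatter, so no order between compound 3 and compound 1 is claimed; only compound 2 sits beyond the scatter from compound 3.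

Compound 4 `CCOC(=O)C1=C(C)NC(C)=C(C(=O)OCCOC)C1c1cnc(SC)n1Nc1ccccc1` has not been measured in this assay. Its relation to compound 3 is 2-methoxyethyl in place of isopropyl on an oxygen next to a carbonyl group. Going by the values given here, this is the same change as the one from compound 1 to compound 2, and the place is described in the same words in both cases; the two cores differ by methyl in place of hydrogen on a saturated chain carbon bound to an oxygen next to a carbonyl group. The expectation for compound 4 rests on the measured pair, because a 1.5-fold higher number from compound 1 to compound 2 (0.18 log units; within the scatter) was small and within the scatter. For compound 4 a step of a 1.5-fold higher number from compound 3 to compound 4 (0.17 log units; within the scatter) in this assay is therefore expected, on a par with the earlier one. Compound 4 is estimated at 4.8 nM in this assay, with the likely range running from 2.4 nM to 10 nM.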

Compound 4, half-maximal inhibitory concentration: 2.91 nM
Estimate against measurement, compound 4: 1.6-fold (0.22 log units) above, and the stated range covers the measured number.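

In this assay, 2-methoxyethyl in place of isopropyl on an oxygen next to a carbonyl group gives a 1.1-fold lower number from compound 3 to compound 4 (0.04 log units; within the scatter), and the two readings of this change on the two cores do not differ: the same change on two cores in this assay, a 1.5-fold higher number (0.18 log units; within the scatter) from compound 1 to compound 2 and a 1.1-fold lower number (0.04 log units; within the scatter) from compound 3 to compound 4, 1.7-fold (0.23 log units) apart, within the scatter of two such steps. The other change in the set, methyl in place of hydrogen on a saturated chain carbon bound to an oxygen next to a carbonyl group, gives a 3.3-fold lower number from compound 2 to compound 4 (0.52 log units; beyond the scatter); this step lies beyond the scatter while its earlier counterpart lies within it, yet the gap between the two is not a real difference: the same change on two cores in this assay, a 2.0-fold lower number (0.29 log units; within the scatter) from compound 1 to compound 3 and a 3.3-fold lower number (0.52 log units; beyond the scatter) from compound 2 to compound 4, 1.7-fold (0.23 log units) apart, within the scatter of two such steps. Both changes therefore carry from one core to the other within the scatter in this small set, but this rests on one pair of cores in one assay, and it does not show that either change would carry to any further core or fix the true size of either step.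

Still open, on these data alone, is whether a longer chain on the same oxygen, or a chain ending in an amine, would behave as 2-methoxyethyl does here. Also open is whether a carboxylic acid in place of either ester would fit the same picture, since every compound shown carries an ester on both sides of the shared core.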